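Working notes on cytotoxicity in a small compound series

A few compounds are considered here, and "the series" means these few. Any claim that something is new, unique, unknown or untested is made for them only; others in the source may bear on it.

Measured in an ADME assay on L6 cells (Rattus norvegicus) for cytotoxicity, read by resazurin assay, with a stated time of 72 h; on this read-out higher numbers stand for weaker inhibition and lower numbers for stronger inhibition:
compound 1 `CN1CCN(CC(=O)OC2CC3(N4CCCC4)CC(c4ccccc4)C2C(c2ccccc2)C3)CC1` gives 24600 nM
compound 2 `O=C(CN1CCCCC1)OC1CC2(N3CCCC3)CC(c3ccccc3)C1C(c1ccccc1)C2` gives 14200 nM
compound 3 `CN1CCN(CC(=O)OC2CC3(N4CCCCC4)CC(c4ccccc4)C2C(c2ccccc2)C3)CC1` gives 29500 nM

Compound 2 differs from compound 1 by piperidin-1-yl in place of 4-methylpiperazin-1-yl on a saturated chain carbon bound to a carbonyl carbon, and this gave a 1.7-fold lower number from compound 1 to compound 2 (0.24 log units; within the scatter). Compound 3 differs from compound 1 in the core, by piperidin-1-yl in place of pyrrolidin-1-yl on a saturated ring carbon, and this gave a 1.2-fold higher number from compound 1 to compound 3 (0.08 log units; within the scatter). The values of compound 1 and compound 3 lie within the scatter of each other, and only the gap between compound 3 and compound 2 is beyond it. Nothing else has been measured in this set.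

Compound 4 `O=C(CN1CCCCC1)OC1CC2(N3CCCCC3)CC(c3ccccc3)C1C(c1ccccc1)C2` has not yet been measured. Among the compounds with values here, it differs from compound 3 by piperidin-1-yl in place of 4-methylpiperazin-1-yl on a saturated chain carbon bound to a carbonyl carbon; this is the same change as the one from compound 1 to compound 2, at the same place. Because that change gave a 1.7-fold lower number from compound 1 to compound 2 (0.24 log units; within the scatter) on the core of compound 1, a step of about a 1.6-fold lower number from compound 3 to compound 4 (0.19 log units; within the scatter) is expected here. Within the data shown here, the only evidence for the size of this step is that single pair, so the range is kept wide. Compound 4 is therefore estimated at 19000 nM in this assay, with a likely span from 9000 nM to 40000 nM.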

Compound 4, half-maximal inhibitory concentration: 60400 nM
Compound 4: the middle estimate sits 3.2-fold (0.50 log units) below what was measured; the measured number lies above the stated range.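

In this assay, piperidin-1-yl in place of 4-methylpiperazin-1-yl on a saturated chain carbon bound to a carbonyl carbon gave a 2.0-fold higher number from compound 3 to compound 4 (0.31 log units; beyond the scatter), so this change does not carry over unchanged from the core of compound 1 to the core of compound 3: the same change on two cores in this assay, a 1.7-fold lower number (0.24 log units; within the scatter) from compound 1 to compound 2 and a 2.0-fold higher number (0.31 log units; beyond the scatter) from compound 3 to compound 4, 3.5-fold (0.55 log units) apart, beyond the scatter of two such steps
Likewise, piperidin-1-yl in place of pyrrolidin-1-yl on a saturated ring carbon gave a 4.3-fold higher number from compound 2 to compound 4 (0.63 log units; beyond the scatter), so the two changes do not simply add up in this series: the same change on two cores in this assay, a 1.2-fold higher number (0.08 log units; within the scatter) from compound 1 to compound 3 and a 4.3-fold higher number (0.63 log units; beyond the scatter) from compound 2 to compound 4, 3.5-fold (0.55 log units) apart, beyond the scatter of two such steps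
This shows that the size of each step depends on the other group present, but it rests on four compounds only, and with the step from compound 1 to compound 2 within the scatter, a true reversal of direction is not established, nor does any reason for the dependence follow.

The compounds shown leave open whether this dependence also holds for other amines on the chain, such as morpholin-4-yl or dimethylamino. They also leave open how azepan-1-yl on the saturated ring carbon would behave.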